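The source may hold more compounds than are shown below. What is called first, only, known or untested is meant among the compounds shown, and "the series" means these compounds.

Of the compounds shown here, three have been tested in a functional assay (thoracic aorta) with Rattus norvegicus as the target (a higher number here means that more compound is needed for the effect, a lower number that less compound is needed), so far. Compound 1, `S=C=Nc1ccc(OCC2=NCCN2)cc1`, gives 69000 nM in this assay. Compound 2, `Cc1ccc(CC2=NCCN2)cc1`, gives 57000 nM in this assay, and compound 3, `O=C(CI)Nc1ccc(CC2=NCCN2)cc1`, gives 47000 nM in this assay. Compound 2 therefore stands among three numbers that all lie within the usual scatter of one another; none of them can be called stronger or weaker than another on this evidence.

Compound 4, `S=C=Nc1ccc(CC2=NCCN2)cc1`, is not yet measured. It differs from compound 2 in one place: a group of 3 heavy atoms (1 carbon, 1 nitrogen, 1 sulfur; no ring) in place of one carbon atom, on an aromatic carbon. Within the data shown here, the only measured step at the same place is a 1.2-fold lower number from compound 2 to compound 3 (0.08 log units; within the scatter), where a much larger group entered without moving the number beyond the scatter. Compound 1, which carries the same entering group as compound 4 on a different linker, also gives a number in the same range. The expectation is therefore no change at the digits printed from compound 2 to compound 4 (within the scatter), a step not beyond the scatter. Compound 4 is estimated at 57000 nM in this assay, with a plausible range from 25000 nM to 130000 nM.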

Compound 4, half-maximal effective concentration: 48000 nM
Beside the measured number, compound 4's estimate is 1.2-fold (0.07 log units) above it; the measured number falls inside the stated range.
By their numbers in this assay, from the lowest: compounds 3, 4, 2 and 1 (each within the scatter of the next).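

Putting the group of 3 heavy atoms in place of methyl gives a 1.2-fold lower number from compound 2 to compound 4 (0.07 log units; within the scatter) in this assay and so adds a second replacement at this aromatic carbon, one much smaller than ((iodomethyl)carbonyl)amino. Comparing the two entering groups directly gives a 1.0-fold higher number from compound 3 to compound 4 (0.01 log units; within the scatter) and so shows that, on the core of compound 2, this read-out does not separate methyl or either of the two larger groups tried in its place. No measurement shown here offers an explanation for this result.

Going by these compounds, only these three groups have been read at this place, so it remains open whether an amine or a carboxylic acid there would give a step beyond the scatter. The same question stands for a longer chain, such as propyl.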